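An acid on the side chain of compound 3

The compounds below may be only part of what the source reports. "The series", "measured", "known", "first", "only" and "open" are said of these compounds alone.

In a functional assay on the whole organism with Rattus norvegicus as the target (on this read-out higher numbers stand for an effect only at larger amounts of compound and lower numbers for an effect already at smaller amounts), compound 1 `Nc1nc2ccc(C3CCCCC3)cc2s1` gives only a limit (> 10 mg/kg) and no number. Compound 2 `CCC(C)(C)c1ccc2nc(N)sc2c1` also gives only a limit (> 10 mg/kg) there. Among the measured compounds shown here, compound 3 `CCn1c(=N)sc2cc(OC(F)(F)F)ccc21` is the only one with a number, 5 mg/kg in this assay. Compound 4 `N=c1sc2cc(OC(F)(F)F)ccc2n1CC(=O)O` differs from compound 3 by carboxy in place of methyl on a saturated chain carbon bound to an aromatic nitrogen. For the measured compounds named here, no measured pair shows this change, so the expectation is a loose one: a move toward larger doses in this assay, starting from compound 3 at 5 mg/kg on that scale. The expected change, a 3.0-fold higher number from compound 3 to compound 4 (0.48 log units; beyond the scatter), is only an estimate. For compound 4 the expected dose is 15 mg/kg (estimated range 5 mg/kg to 50 mg/kg), and a report of only a limit would not surprise.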

Compound 4, dose for half-maximal effect: > 10 mg/kg
Compound 4 gave a limit, no number (the forecaster's own chance of this, stated with the estimate: 60%); the middle value is on the limit's open side.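

Carboxy in place of methyl on a saturated chain carbon bound to an aromatic nitrogen gives, in this assay, an at least 2.0-fold higher number from compound 3 to compound 4 (0.30 log units; that floor lies within the scatter). This is the first step shown at this position, and it sets only a floor, so its true size stays unknown and a change beyond the scatter is not established. The value of compound 4 is a limit, so this read-out gives no number for it: the limit of > 10 mg/kg in this assay, at which 3 of the 4 values shown sit.

The compounds shown leave open whether an amine or a longer chain at this place would give a number on this scale.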